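Swapping the Dichlorothiophene Ring for a Hydroxybenzamide

This account rests on a few compounds, and the source may have more. Where it says the series, first, only, none or still open, it means among the compounds named here.

Compound 1 `CS(=O)(=O)c1ccc(Cc2nnc3n2N=C(c2cc(Cl)sc2Cl)CS3)cc1` was tested in a functional assay on HT-29 cells (Homo sapiens) for cytotoxicity, read by MTT assay, with a stated time of 48 h, tested at 25 uM (on this read-out higher numbers stand for a stronger effect at the one concentration tested and lower numbers for a weaker effect), and gives "not active" (no number reported), so no single number marks where it stands; it is known only to have shown no effect that could be put into figures. Compound 2 `CS(=O)(=O)c1ccc(Cc2nnc3n2N=C(c2cc4ccccc4c(=O)o2)CS3)cc1`, built on the same core, shows that this core can carry some activity: in this assay compound 2 gives 25.6%. Compound 3 `CS(=O)(=O)c1ccc(Cc2nnc3n2N=C(c2ccc(O)c(C(N)=O)c2)CS3)cc1` is now to be measured. It differs from compound 1 in one place: 3-carbamoyl-4-hydroxyphenyl in place of 2,5-dichlorothiophen-3-yl on a carbon with a double bond to nitrogen. Among the measured compounds shown here, no measured step exists for this kind of change, so its size can only be guessed. Since compound 1 gives "not active" (no number reported), the start lies at the bottom of the scale, and any change would be upward; a small to modest rise, at most around the edge of the usual scatter, is expected. Compound 3 is therefore estimated to give 12%, within a range from 0% to 30%.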

Compound 3, a percentage reported as activity, at one concentration (the size of the read-out at that concentration, not a potency): 24.7%
Beside the measured number, compound 3's estimate is 12.7 percentage points below it; the measured number falls inside the stated range.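

Among the compounds shown here, compound 1 gives "not active" (no number reported) and so offers no number to start from, which means no step to compound 3 can be read. The compounds shown leave open how large the effect of this swap is. Nothing measured here explains the activity of compound 3.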